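The compounds below may be only part of what the source reports. "The series", "measured", "known", "first", "only" and "open" are said of these compounds alone.

The measured compounds:

Compound 1 `O=C(NCN1CCC(c2cccc[n+]2[O-])CC1)c1ccccc1` gives 532 nM in a functional assay on HEK293 cells for agonist activity at D(4) dopamine receptor (Homo sapiens), read by FLIPR; a higher number here means that more compound is needed for the effect, a lower number that less compound is needed.
Compound 2 `CSc1cccc(NC(=O)CN2CCC(c3cccc[n+]3[O-])CC2)c1` gives 100 nM in this assay.
Compound 3 `Cc1cc(Cl)cc(C)c1NC(=O)CN1CCC(c2ccccn2)CC1` gives 240 nM in this assay.

Among these three numbers compound 1 stands highest. Compound 3 comes nearest to it, with a number lower by a margin beyond the usual scatter, and compound 2 lies furthest away, lower still. The two lower numbers belong to compounds whose structures differ from compound 1 in more than one place, so neither gives a clean step against which a single change can be read.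

Compound 4 `Cc1cc(C(=O)NCN2CCC(c3cccc[n+]3[O-])CC2)ccc1Cl` has not yet been measured in this assay. It differs from compound 1 in one place: 4-chloro-3-methylphenyl in place of phenyl on a carbonyl carbon. For the measured compounds named here, no pair of measured compounds isolates this change, so the expectation rests on the value of compound 1 and on the width of the set, in which every other compound sits below it. The step of a 2.0-fold lower number from compound 1 to compound 4 (0.31 log units; beyond the scatter) is expected to be a moderate lowering of the number, though a step no larger than the scatter cannot be excluded. Compound 4 is accordingly estimated at 260 nM, with a range from 80 nM to 850 nM within which most repeat measurements should fall.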

Compound 4, half-maximal effective concentration: 2460 nM
Estimate against measurement, compound 4: 9.5-fold (0.98 log units) below; measured number outside the range, above it.
By their numbers in this assay, from the lowest: compound 2; then compound 3; then compound 1; then compound 4.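

Putting 4-chloro-3-methylphenyl in place of phenyl on a carbonyl carbon gives a 4.6-fold higher number from compound 1 to compound 4 (0.67 log units; beyond the scatter) in this assay. For the compounds shown here, this is the first step in the set that isolates a single change, and it shows that the group on this carbonyl carbon is not indifferent: the swap keeps one six-membered aromatic ring of carbon only and leaves the donor and acceptor counts as they were, yet the number rises beyond the scatter, so that more compound is needed for the effect. Nothing available bears on why the number moves this way.

The chlorine and the methyl enter together in compound 4, so the compounds shown cannot say which of them goes with the rise, or whether both are needed; a 4-chlorophenyl or a 3-methylphenyl at this place would separate the two. They also leave open whether the number responds in the same direction to a group other than a substituted phenyl here, such as a cyclohexyl or a pyridine ring.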